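The source may hold more compounds than are shown below. What is called first, only, known or untested is meant among the compounds shown, and "the series" means these compounds.

Measured so far in a functional assay on HeLa cells (Homo sapiens) for cytotoxicity, read by MTT assay; on this read-out lower numbers stand for stronger inhibition and higher numbers for weaker inhibition:

Compound 1 `CC(C)=CC[C@@H](OC(=O)CC(C)(O)c1ccccc1)C1=CC(=O)c2c(O)ccc(O)c2C1=O` gives 85700 nM.
Compound 2 `CCCC(O)CC(=O)O[C@H](CC=C(C)C)C1=CC(=O)c2c(O)ccc(O)c2C1=O` gives 59300 nM.
Compound 3 `CC(C)=CC[C@@H](OC(=O)CC(O)c1ccccc1)C1=CC(=O)c2c(O)ccc(O)c2C1=O` gives 44500 nM.

Compound 2 holds the second highest of the three numbers; toward compound 3 the step is a 1.3-fold lower number from compound 2 to compound 3 (0.12 log units; within the scatter), and the step of a 1.4-fold lower number from compound 1 to compound 2 (0.16 log units; within the scatter) is likewise within the scatter, as is a 1.9-fold lower number from compound 1 to compound 3 (0.28 log units; within the scatter). Compound 4 `CC(=O)OC(C)CO[C@H](CC=C(C)C)C1=CC(=O)c2c(O)ccc(O)c2C1=O` is the next candidate. Its change from compound 2 is 2-acetoxypropyl in place of (2-hydroxypentyl)carbonyl on an oxygen on a saturated carbon. For the measured compounds named here, no measured step touches this part of the molecule: the three known steps only exchange groups further out on the side chain, and all three stay within the scatter. The account therefore carries no expectation of a step beyond the scatter in this assay. Compound 4 is expected near 60000 nM, within 28000 nM to 130000 nM, an expected step of a 1.0-fold higher number from compound 2 to compound 4 (0.01 log units; within the scatter).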

Compound 4, half-maximal inhibitory concentration: 40100 nM
The estimate for compound 4 lay 1.5-fold (0.18 log units) above the measured number, and the stated range covers the measured number.
By their numbers in this assay, from the lowest: compounds 4, 3, 2 and 1 (each within the scatter of the next, the first and the last beyond it).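

In this assay, putting 2-acetoxypropyl in place of (2-hydroxypentyl)carbonyl changes the group on this oxygen itself, not a group further out on the side chain, and the result is a small step (a 1.5-fold lower number from compound 2 to compound 4 (0.17 log units; within the scatter)). Even with the hydrogen-bond donor of the leaving group gone, this step stays within the scatter. Nothing available explains this result.

The compounds shown leave open whether an amine or a carboxylic acid on this oxygen would give a step beyond the scatter. The same question stands for a longer chain.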